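The source may report more compounds than this note shows. Statements on the series, on what has been measured and on what is new or still open speak of the compounds shown alone.

Series notes. Three members have numbers in an ADME assay for permeability, using PAMPA, with a stated time of 4 h, at pH 5.5; on this read-out higher numbers stand for higher permeability and lower numbers for lower permeability. Compound 1 `NCCCCN(C[C@@H]1Cc2ncccc2CN1)[C@H]1CCCc2cccnc21` gives 2 nm/s in this assay. Compound 2 `NC/C=C/CN(C[C@H]1Cc2ncccc2CN1)[C@H]1CCCc2cccnc21` gives 2 nm/s in this assay; on the numbers shown it is level with compound 1 at the digits printed, the two together the lowest of the three, and the gap between them lies within the scatter. Compound 3 `CN(CCCCN(C[C@H]1Cc2ncccc2CN1)[C@H]1CCCc2cccnc21)C1CCC(F)(F)CC1` gives 15 nm/s in this assay, which is the number furthest from compound 2, beyond the scatter.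

The next step goes from compound 2 to compound 4 `CN(CCCCN(C[C@H]1Cc2ncccc2CN1)[C@H]1CCCc2cccnc21)C1CCOCC1`. The change: a group of 11 heavy atoms (9 carbon, 1 nitrogen, 1 oxygen; one six-membered non-aromatic ring with 1 hetero atom) in place of a group of 4 heavy atoms (3 carbon, 1 nitrogen; no ring), on a saturated chain carbon bound to an amine nitrogen. Going by the values given here, no pair of measured compounds differs in this one place alone, so no step of that exact kind is at hand. Compound 3 stands at 15 nm/s in this assay and is the nearest pointer for the direction. Compound 4 is expected to move upward in this assay, a 3.5-fold higher number from compound 2 to compound 4 (0.54 log units; beyond the scatter), a step judged likely to be beyond the scatter but not firmly so, because compound 3 reaches only 15 nm/s in this assay. The estimate for compound 4 in this assay is 7 nm/s, with a range from 2 nm/s to 20 nm/s.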

Compound 4, apparent permeability: 15 nm/s
The estimate for compound 4 lay 2.1-fold (0.33 log units) below the measured number, within the range that was stated.
By their numbers in this assay, from the lowest: compounds 1 and 2 (each within the scatter of the next); then compounds 3 and 4 (each within the scatter of the next).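

In this assay, the change on a saturated chain carbon bound to an amine nitrogen gives a 7.5-fold higher number from compound 2 to compound 4 (0.88 log units; beyond the scatter), a step beyond the scatter: the 3-aminoprop-1-en-1-yl group with its double bond and hydrogen-bond donor leaves, and a larger group with a six-membered non-aromatic ring and no hydrogen-bond donor enters. The end of the larger group can also be exchanged, since oxan-4-yl in place of 4,4-difluorocyclohexyl on an amine nitrogen gives no change at the digits printed from compound 3 to compound 4 (within the scatter), so on this read-out the two ring ends cannot be told apart, and the number reached by compound 3 is not specific to that one ring. No measurement at hand bears on what lies behind either step.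

The step from compound 2 to compound 4 alters the double bond, the amine and the ring together, so the share of each in the higher number remains unresolved. A saturated chain ending in a dimethylamino group, or an unsubstituted cyclohexyl or a carboxylic acid at the end of the same chain, would begin to separate these parts.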